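Bromo for Fluoro on Two Related Cores

The source may report more compounds than this note shows. Statements on the series, on what has been measured and on what is new or still open speak of the compounds shown alone.

In a functional assay on PC-3 cells (Homo sapiens) (a lower number here means a stronger inhibitor of growth, a higher number a weaker inhibitor of growth), three compounds have been measured:

Compound 1 `O=S(=O)(/C=C/c1ccc(F)cc1)Cc1ccc(Nc2ncnc3ccccc23)cc1`: 1000 nM
Compound 2 `O=S(=O)(/C=C/c1ccc(Br)cc1)Cc1ccc(Nc2ncnc3ccccc23)cc1`: 42000 nM
Compound 3 `COc1cc2ncnc(Nc3ccc(CS(=O)(=O)/C=C/c4ccc(F)cc4)cc3)c2cc1OC`: > 100000 nM, which is a limit of the assay and not a number.

Compounds 1 and 2 share a core and differ in one place, (bromo in place of fluoro on an aromatic carbon). This change gave a 42-fold higher number from compound 1 to compound 2 (1.62 log units; beyond the scatter), a step that stands out clearly against the usual scatter. Compound 3 sits at the limit of > 100000 nM in this assay, at which 1 of the 3 values shown sits. How the core of compound 3 differs from the core of compound 1 is not broken down here.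

Compound 4 `COc1cc2ncnc(Nc3ccc(CS(=O)(=O)/C=C/c4ccc(Br)cc4)cc3)c2cc1OC` is not yet measured. It is related to compound 3 by the same change, (bromo in place of fluoro on an aromatic carbon), with the place described in the same words as for the step from compound 1 to compound 2. Since compound 3 already gives only a limit, and the same change lowered the growth inhibition between compound 1 and compound 2 by a 42-fold higher number from compound 1 to compound 2 (1.62 log units; beyond the scatter), compound 4 is expected to give a step that the limit leaves unreadable from compound 3 to compound 4 in this assay, most probably again reported as a limit only. The estimate for compound 4 in this assay is therefore 400000 nM, with a range from 100000 nM to 3000000 nM.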

Compound 4, concentration for 50% growth inhibition: 9500 nM
Beside the measured number, compound 4's estimate is 42-fold (1.62 log units) above it; the whole stated range lies above it.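

In this assay, bromo in place of fluoro does not carry over from one core to the other, and the two steps point in opposite directions: the same change on two cores in this assay, a 42-fold higher number (1.62 log units; beyond the scatter) from compound 1 to compound 2 and an at least 10-fold lower number (1.02 log units; beyond the scatter) from compound 3 to compound 4, at least 440-fold (2.64 log units) apart, beyond the scatter of two such steps

Compound 3 stands at a limit of the assay and not at a number: the limit of > 100000 nM in this assay, at which 1 of the 4 values shown sits.

The result is an at least 10-fold lower number from compound 3 to compound 4 (1.02 log units; beyond the scatter), so the direction is clear while the true size remains unknown and could be larger; this shows that the effect of this swap on one core is a poor guide to its effect on the other, but it does not show why the direction reverses, or which direction a third core would follow.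

Going by these compounds, whether chloro or methyl in the same place, on the 4-fluorophenyl ring of each core, would follow the step on the core of compound 1 or the step on the core of compound 3 remains open. Also open, on these data alone, is whether the reversal depends on the whole core of compound 3 or on only one part of it.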